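Amide tail swap on the nitro sulfone acid

The source may report more compounds than this note shows. Statements on the series, on what has been measured and on what is new or still open speak of the compounds shown alone.

Compound 2, `CS(=O)(=O)c1ccc(C(=O)NCCC(=O)N2CCCc3ccccc32)cc1[N+](=O)[O-]`, is the reference point here. In an assay on isolated protein for inhibition of thyroid hormone receptor beta (Homo sapiens), read by fluorescence polarization (a lower number here means a stronger inhibitor, a higher number a weaker inhibitor), compound 2 gives > 60000 nM, which is a limit of the assay and not a number. Its two neighbours in the series fare the same way. Compound 1, `CS(=O)(=O)c1ccc(C(=O)N2CCC(C(=O)N3CCc4ccccc43)CC2)cc1[N+](=O)[O-]`, in this assay gives > 60000 nM, again a limit. Compound 3, `CN(Cc1ccccc1)C(=O)C1CCN(C(=O)c2ccc(S(C)(=O)=O)c([N+](=O)[O-])c2)CC1`, gives > 60000 nM in this assay, also a limit. Among the measured compounds shown here, the one change that can be followed between measured compounds, a step that the two limits leave unreadable from compound 1 to compound 3, is not readable in size because of the limit of > 60000 nM in this assay, at which 3 of the 3 values shown sit. Compound 4, `CC(C)N(C(=O)CCNC(=O)c1ccc(S(C)(=O)=O)c([N+](=O)[O-])c1)C(C)C`, is the next member. Its change from compound 2 is diisopropylamino in place of 1,2,3,4-tetrahydroquinolin-1-yl on a carbonyl carbon. For the measured compounds named here, no measured step matches this swap; the only measured exchange on a carbonyl carbon sits between two limits and tells nothing about direction. On this basis no gain beyond the scatter is expected for compound 4, and a step that the limit leaves unreadable from compound 2 to compound 4 from compound 2 is the estimate. The expected value for compound 4 in this assay is 100000 nM, with a range from 30000 nM to 300000 nM, and most likely it will again be reported only as a limit.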

Compound 4, half-maximal inhibitory concentration: > 60000 nM
Compound 4 gave a limit, no number (the forecaster's own chance of this, stated with the estimate: 90%); the middle value does not contradict the limit.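

No new step can be read from compound 2 to compound 4, because both results are limits of the assay and not numbers: the limit of > 60000 nM in this assay, at which 4 of the 4 values shown sit.

The compounds shown leave open which amide tail on the shared core, if any, would give a numerical half-maximal inhibitory concentration in this assay.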